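Phenyl in place of ethoxycarbonyl on compound 3

This account rests on a few compounds, and the source may have more. Where it says the series, first, only, none or still open, it means among the compounds named here.

Of the compounds shown here, three have been measured so far in an ADME assay on cells (Peritoneal macrophage, Mus musculus, strain Swiss) for cytotoxicity, with a stated time of 24 h; on this read-out lower numbers stand for higher toxicity in this test and higher numbers for lower toxicity in this test. Compound 1 (`O=C1C(Cl)=C(Cl)C(=O)c2c(I)cccc21`) gives 27800 nM, compound 2 (`CC1=C(C)C(=O)C(I)=CC1=O`) gives 15400 nM and compound 3 (`CCOC(=O)/C=C/c1cccc2c1C(=O)C=CC2=O`) gives 12700 nM. Compound 3 stands within the scatter of compound 2, and beyond the scatter of compound 1, on the side of higher toxicity in this test.

The next compound to be read is compound 4 (`O=C1C=CC(=O)c2c(/C=C/c3ccccc3)cccc21`), which differs from compound 3 in one place: phenyl in place of ethoxycarbonyl on a double-bonded chain carbon bound to a double-bonded chain carbon. In words, this is phenyl in place of ethoxycarbonyl on a double-bonded chain carbon bound to a double-bonded chain carbon.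

Among the measured compounds shown here, no measured pair shows this change or any other single change, so the size of the step cannot be read from the data. For the measured compounds named here, the only guide is the modest spread of the measured values, with compound 3 at 12700 nM and compound 1 at 27800 nM, although their structures differ in more than one place. In this assay no change beyond the scatter is expected, and the estimated step is a 1.2-fold lower number from compound 3 to compound 4 (0.06 log units; within the scatter). The range is kept wide to reflect how little the series says about this change. Compound 4 is expected at 11000 nM, with an estimated range of 5000 nM to 25000 nM.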

Compound 4, concentration lethal to 50% of the cells: 11900 nM
Beside the measured number, compound 4's estimate is 1.1-fold (0.03 log units) below it, within the range that was stated.
By their numbers in this assay, from the lowest: compounds 4, 3, 2 and 1 (each within the scatter of the next, the first and the last beyond it).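

Among the compounds shown here, this is the first comparison in which only one place differs: in this assay, phenyl in place of ethoxycarbonyl on a double-bonded chain carbon bound to a double-bonded chain carbon gives a 1.1-fold lower number from compound 3 to compound 4 (0.03 log units; within the scatter). At this place, a group with one six-membered aromatic ring of carbon only and 0 hydrogen-bond acceptors and a group with no ring and 2 hydrogen-bond acceptors therefore give numbers within the scatter of each other. No available measurement bears on why these two numbers lie so close.

Only these two groups are shown at this place, so it remains open whether an amine, a carboxylic acid or a longer chain there would also stay within the scatter of compound 3 in this assay. Also open, as far as these compounds go, is whether phenyl in place of ethoxycarbonyl would read the same way on another core, since compound 1 and compound 2 are not single-place partners of either compound in this pair.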